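The compounds below may be only part of what the source reports. "The series", "measured", "known", "first", "only" and "open" are said of these compounds alone.

Of the compounds shown here, three that share one core have been measured so far. In a functional assay (on this read-out lower numbers stand for stronger inhibition and higher numbers for weaker inhibition), compound 1, `C=CC(C)(C)c1[nH]c2ccc(C[C@@H](O)C(=C)C)cc2c1/C=C1\NC(=O)[C@H](C)NC1=O`, gives 75000 nM. Compound 2, `C=CC(C)(C)c1[nH]c2ccccc2c1/C=C1\NC(=O)C(C)(OC)NC1=O`, gives 99000 nM in this assay, and compound 3, `C=CC(C)(C)c1[nH]c2ccc(CC=C(C)C)cc2c1/C=C1\NC(=O)C(=O)NC1=O`, gives 102000 nM. Compound 1 carries the smallest of the three numbers, yet its gaps to compound 2 and to compound 3 both stay within the scatter, so the three cannot be told apart. Compound 4, `C=CC(C)(C)c1[nH]c2ccc(CC=C(C)C)cc2c1/C=C1\NC(=O)[C@H](C)NC1=O`, has not yet been measured. It differs from compound 1 in one place: 2-methylprop-1-en-1-yl in place of 1-hydroxy-2-methylprop-2-en-1-yl on a saturated chain carbon bound to an aromatic carbon. For the measured compounds named here, no measured step bears on this change, so compound 4 is expected to land near compound 1, with an estimated step of a 1.1-fold higher number from compound 1 to compound 4 (0.03 log units; within the scatter), meaning nothing beyond the scatter in either direction. Compound 4 is therefore expected at 80000 nM, with a range from 30000 nM to 200000 nM.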

Compound 4, half-maximal inhibitory concentration: 98000 nM
The estimate for compound 4 lay 1.2-fold (0.09 log units) below the measured number; the measured number falls inside the stated range.
By their numbers in this assay, from the lowest: compounds 1, 4, 2 and 3 (each within the scatter of the next).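

In this assay, this place, a saturated chain carbon bound to an aromatic carbon, now has its first readable step, a 1.3-fold higher number from compound 1 to compound 4 (0.12 log units; within the scatter), which stays within the scatter. The change takes out the hydroxyl of 1-hydroxy-2-methylprop-2-en-1-yl, and 2-methylprop-1-en-1-yl carries no hydrogen-bond donor or acceptor, yet the two compounds cannot be told apart. No supporting data bear on this result.

Going by these compounds, it remains open whether an amine, a carboxylic acid or a longer chain at this place would give a step beyond the scatter.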